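A Benzyl Swap on a Shared Core

The source may report more compounds than this note shows. Statements on the series, on what has been measured and on what is new or still open speak of the compounds shown alone.

Of the compounds shown here, three built on one shared core have been tested in a functional assay on SK-OV-3 cells (Homo sapiens) for cytotoxicity, read by MTT assay, with a stated time of 2 days; a lower number here means a stronger inhibitor, a higher number a weaker inhibitor. Compound 1 `c1ccc(CO/N=C2/C(c3c[nH]c4ccccc34)=Nc3ccccc32)cc1` gives 16900 nM, and compound 2 `N#Cc1ccc2c(c1)/C(=N\OCc1ccccc1)C(c1c[nH]c3ccc(C#N)cc13)=N2` gives 16600 nM. Compound 3 `Cc1ccc(CO/N=C2/C(c3c[nH]c4ccc(Br)cc34)=Nc3ccc(Br)cc32)cc1` gives 7220 nM, the lowest number of the three, with compound 2 and compound 1 both standing higher by more than the usual scatter. Compound 4 `Clc1cccc(CO/N=C2/C(c3c[nH]c4ccc(Br)cc34)=Nc3ccc(Br)cc32)c1` has not yet been measured in this assay; it differs from compound 3 in one place: 3-chlorophenyl in place of 4-methylphenyl on a saturated chain carbon bound to an oxygen on an unsaturated carbon. Among the measured compounds shown here, no measured pair shows this kind of change, so there is no direct comparison to lean on. The step from compound 3 to compound 4 is expected to be small, a 1.1-fold lower number from compound 3 to compound 4 (0.05 log units; within the scatter), probably within the scatter in either direction. Compound 4 is therefore estimated at 6500 nM, with a range from 2500 nM to 16000 nM.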

Compound 4, half-maximal inhibitory concentration: 14100 nM
The estimate for compound 4 lay 2.2-fold (0.34 log units) below the measured number, and the stated range covers the measured number.
By their numbers in this assay, from the lowest: compounds 3, 4, 2 and 1 (each within the scatter of the next, the first and the last beyond it).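

Among the compounds shown here, this is the first direct view of the benzyl end of the shared core. In this assay, putting 3-chlorophenyl in place of 4-methylphenyl gives a 2.0-fold higher number from compound 3 to compound 4 (0.29 log units; within the scatter) and so does not separate the two groups at this position. Nothing at hand explains the result. Still open, as far as these compounds go, is how this position would respond to a different kind of group on the saturated chain carbon, such as an amine, a carboxylic acid or a longer chain in place of the aromatic ring.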